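Replacing Dimethoxyphenyl with Methylphenyl on the Amide

The source may report more compounds than this note shows. Statements on the series, on what has been measured and on what is new or still open speak of the compounds shown alone.

Compound 1 `COc1ccc(NC(=O)CN2CCN(c3nnc(Cc4ccncc4)c4ccccc34)CC2)cc1OC` gives 100 nM in a functional assay on MDA-MB-231 cells (Homo sapiens) for cytotoxicity, read by MTT assay, with a stated time of 72 h (on this read-out lower numbers stand for stronger inhibition and higher numbers for weaker inhibition), the lowest of the two numbers measured. Compound 2 `Cc1ccc(F)cc1NC(=O)CN1CCN(c2nnc(Cc3ccccc3)c3ccccc23)CC1` differs from it in two places and gives 19200 nM, a gap well beyond the scatter, so neither of its two changes can be weighed on its own. Compound 3 `Cc1ccccc1NC(=O)CN1CCN(c2nnc(Cc3ccncc3)c3ccccc23)CC1` keeps the pyridinylmethyl arm of compound 1 and carries 2-methylphenyl in place of 3,4-dimethoxyphenyl on an amide-type nitrogen. Among the compounds with values here, no single-change step exists to guide the size; given the weaker result of compound 2 with its related amide-side aryl at 19200 nM, a loss of some size is expected for compound 3, with a 10-fold higher number from compound 1 to compound 3 (1.00 log units; beyond the scatter). Compound 3 is estimated at 1000 nM, within 150 nM to 8000 nM.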

Compound 3, half-maximal inhibitory concentration: 200 nM
Beside the measured number, compound 3's estimate is 5.0-fold (0.70 log units) above it, and the stated range covers the measured number.
By their numbers in this assay, from the lowest: compounds 1 and 3 (each within the scatter of the next); then compound 2.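

In this assay, within the data shown here, 2-methylphenyl in place of 3,4-dimethoxyphenyl on an amide-type nitrogen gives a 2.0-fold higher number from compound 1 to compound 3 (0.30 log units; within the scatter), the first single-change reading at this position. With the pyridinylmethyl arm kept, this pair therefore shows no measurable cost when the two oxygen-bearing methoxy groups leave the aryl ring. No measured evidence here accounts for this result. The compounds shown leave open whether an aryl ring carrying an amine or a carboxylic acid would hold up on this nitrogen. They also leave open how much of the number of compound 2 belongs to its benzyl arm and how much to its fluorine.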